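Methoxy replaces (4-methoxybenzyl)amino on the carbonyl carbon

The source may report more compounds than this note shows. Statements on the series, on what has been measured and on what is new or still open speak of the compounds shown alone.

Compound 1 `CC1CN(C(=O)c2c(N)sc(-c3ccc(Cl)cc3)c2-c2ccc(Cl)cc2)CCN1`: 7210 nM
Compound 2 `CCCCNC(=O)c1c(N)sc(-c2ccc(Cl)cc2)c1-c1ccc(Cl)cc1`: 17800 nM
Compound 3 `COc1ccc(CNC(=O)c2c(N)sc(-c3ccc(Cl)cc3)c2-c2ccc(Cl)cc2)cc1`: 29500 nM

In a functional assay on PC-3 cells (Homo sapiens) for inhibition, read by sulforhodamine B assay, with a stated time of 72 h (a lower number here means a stronger inhibitor, a higher number a weaker inhibitor), compound 3 gives 29500 nM. Its nearest neighbour is the butylamino compound, with a 1.7-fold higher number from compound 2 to compound 3 (0.22 log units; within the scatter), and its furthest is the 3-methylpiperazin-1-yl compound, with a 4.1-fold higher number from compound 1 to compound 3 (0.61 log units; beyond the scatter).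

Compound 4 `COC(=O)c1c(N)sc(-c2ccc(Cl)cc2)c1-c1ccc(Cl)cc1` keeps the shared core but carries methoxy in place of (4-methoxybenzyl)amino on a carbonyl carbon. The other measured step at this carbonyl carbon is a 2.5-fold higher number from compound 1 to compound 2 (0.39 log units; beyond the scatter). For the measured compounds named here, no measured compound has methoxy there, so these steps show only how far changes in this group have moved the number so far, from within the scatter to modest.

Compound 1 , at 7210 nM, shows that a lower number is reachable by changing this group. A modest step towards a lower number in this assay is therefore expected, though the direction is less certain than the size. The expected change is a 2.1-fold lower number from compound 3 to compound 4 (0.32 log units; beyond the scatter). For compound 4 the estimated value is 14000 nM, with an expected range from 5000 nM to 40000 nM.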

Compound 4, half-maximal inhibitory concentration: 2780 nM
Compound 4: middle estimate off by 5.0-fold (0.70 log units), on the high side; the measured number lies below the stated range.
By their numbers in this assay, from the lowest: compound 4; then compound 1; then compounds 2 and 3 (each within the scatter of the next).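

In this assay methoxy on the carbonyl carbon gives the lowest number of the series, ahead of all three nitrogen-linked groups (an 11-fold lower number from compound 3 to compound 4 (1.03 log units; beyond the scatter); a 6.4-fold lower number from compound 2 to compound 4 (0.81 log units; beyond the scatter); a 2.6-fold lower number from compound 1 to compound 4 (0.41 log units; beyond the scatter)). The earlier compounds shown here all carried a nitrogen at this carbonyl carbon, so they could not show that a low number needs neither that nitrogen nor a ring in the group, as methoxy now does. No measurement here accounts for the drop.

The compounds shown cannot separate the loss of the nitrogen from the smaller size of the new group, since methoxy differs from the others in both. Ethoxy or a carboxylic acid at this carbonyl carbon would keep the nitrogen out while changing the group, and methylamino would restore the nitrogen in a group of similar size.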